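Aryl Swap on a Shared Core: Cytotoxicity in Melanoma Cells

The compounds below may be only part of what the source reports. "The series", "measured", "known", "first", "only" and "open" are said of these compounds alone.

Measured so far:
compound 1, `COc1ccccc1Oc1c(N)nc(-c2ccc(C)cc2)nc1Cl`: > 80000 nM
compound 2, `COc1ccccc1Oc1c(N)nc(-c2ccccc2F)nc1Cl`: > 80000 nM

In a functional assay on A-375 cells (Homo sapiens) for cytotoxicity, read by CCK-8 assay, with a stated time of 24 h (on this read-out lower numbers stand for stronger inhibition and higher numbers for weaker inhibition), compound 1 returns only a limit, > 80000 nM. Compound 2 likewise returns only a limit in this assay, > 80000 nM. Compound 1 therefore stands nowhere in particular among the numbers shown: both values are limits, and no order between the two compounds can be read. The step that the two limits leave unreadable from compound 1 to compound 2 stays unreadable because the limit of > 80000 nM in this assay, at which 2 of the 2 values shown sit, is where both values sit.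

Compound 3, `COc1ccccc1Oc1c(N)nc(-c2cccc(Cl)c2)nc1Cl`, has not yet been tested in this assay. It differs from compound 1 by 3-chlorophenyl in place of 4-methylphenyl on an aromatic carbon. Within the data shown here, the only measured step that bears on such an aryl exchange is the one from compound 1 to compound 2, and its size cannot be read, so no direction for this assay can be drawn from it. Given that compound 1 sits at > 80000 nM, compound 3 is expected to sit at the same limit rather than at a number. Compound 3 is estimated at 100000 nM, with a range from 30000 nM to 300000 nM. The step expected is a step that the limit leaves unreadable from compound 1 to compound 3.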

Compound 3, half-maximal inhibitory concentration: 38300 nM
Compound 3: the middle estimate sits 2.6-fold (0.42 log units) above what was measured; low and high end bracket the measured number.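

In this assay, the aryl group on the carbon between two ring nitrogen atoms now proves able to move the read-out, which the earlier pair, whose step could not be read, did not show. Putting 3-chlorophenyl at this place gives an at least 2.0-fold lower number from compound 1 to compound 3 (0.31 log units; beyond the scatter), and the same group gives an at least 2.0-fold lower number from compound 2 to compound 3 (0.31 log units; beyond the scatter), so the change lowers the number against both 4-methylphenyl and 2-fluorophenyl by more than the usual scatter. Both steps are only lower bounds on the true size because compound 1 and compound 2 have no exact value to measure from, and the order between those two remains unknown: the limit of > 80000 nM in this assay, at which 2 of the 3 values shown sit.

The compounds shown cannot separate the effect of the chlorine itself from that of the place it holds on the phenyl ring, since 3-chlorophenyl differs from each of the other two groups in both respects. They also leave open how an aryl group carrying an amine or a carboxylic acid would read in this assay, and whether any group at this place could bring the number much lower.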